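The compounds below may be only part of what the source reports. "The series", "measured", "known", "first", "only" and "open" are said of these compounds alone.

Working notes on the series. Three compounds have numbers in a functional assay on DU-145 cells (Homo sapiens) for cytotoxicity, read by MTT assay, with a stated time of 48 h; a higher number here means a weaker inhibitor, a lower number a stronger inhibitor. Going by the values given here, compound 1 `CC(C)=CCC/C(C)=C/CC/C(C)=C/CC[C@@H]1[C@@]2(C)CC/C(=N\OCc3cn(-c4ccccc4)nn3)C(C)(C)[C@@H]2CC[C@@]1(C)O` gives 8830 nM, and compound 2 `CC(C)=CCC/C(C)=C/CC/C(C)=C/CC[C@@H]1[C@@]2(C)CC/C(=N\OCc3cn(-c4ccccc4C#N)nn3)C(C)(C)[C@@H]2CC[C@@]1(C)O` gives 25100 nM; the one step that differs in one place, a 2.8-fold higher number from compound 1 to compound 2 (0.45 log units; beyond the scatter), is the only measured change on the aromatic ring that hangs from the five-membered aromatic ring with 3 nitrogen. Compound 3 `COc1cccc(-n2cc(COc3ccc(/C=C4\C[C@]5(C)[C@@H](CC/C=C(\C)CC/C=C(\C)CCC=C(C)C)[C@](C)(O)CC[C@H]5C(C)(C)C4=O)cc3)nn2)c1` sits on a different core than compound 1 and compound 2. Compound 3 gives 14500 nM; it stands second highest of the three numbers, within the scatter of both compound 1 and compound 2, so no order among the three is claimed.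

Compound 4 `COc1cc(OC)c(-n2cc(COc3ccc(/C=C4\C[C@]5(C)[C@@H](CC/C=C(\C)CC/C=C(\C)CCC=C(C)C)[C@](C)(O)CC[C@H]5C(C)(C)C4=O)cc3)nn2)c(OC)c1` differs from compound 3 in one place: 2,4,6-trimethoxyphenyl in place of 3-methoxyphenyl on an aromatic nitrogen. Among the compounds with values here, no measured step bears directly on this change; the nearest guide is the cyano step between compound 1 and compound 2, which was modest and on another core. Within the data shown here, nothing here shows a large shift from changing substituents on that aromatic ring, so the expected step of a 1.2-fold higher number from compound 3 to compound 4 (0.09 log units; within the scatter) is small, most likely within the scatter, with a slight lean toward a higher number because the only measured change there, a 2.8-fold higher number from compound 1 to compound 2 (0.45 log units; beyond the scatter), went up. The number expected for compound 4 is 18000 nM, between 7000 nM and 45000 nM.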

Compound 4, half-maximal inhibitory concentration: 12000 nM
Estimate against measurement, compound 4: 1.5-fold (0.18 log units) above; low and high end bracket the measured number.
By their numbers in this assay, from the lowest: compounds 1, 4, 3 and 2 (each within the scatter of the next, the first and the last beyond it).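

In this assay, 2,4,6-trimethoxyphenyl in place of 3-methoxyphenyl on the aromatic nitrogen gives a 1.2-fold lower number from compound 3 to compound 4 (0.08 log units; within the scatter), so on the core of compound 3 the two numbers cannot be told apart, although the entering group has 12 heavy atoms against 8 and 3 hydrogen-bond acceptors against 1. The earlier compounds shown here offered only the cyano step on another core, a 2.8-fold higher number from compound 1 to compound 2 (0.45 log units; beyond the scatter), and this new step shows that not every substituent change on the aromatic ring on that nitrogen moves the number beyond the scatter. No measured information on these groups bears on this result.

Open, going by these compounds, is whether an amine or a carboxylic acid on that aromatic ring would move the number beyond the scatter on the core of compound 3. Also open, on these data alone, is how 2,4,6-trimethoxyphenyl would read on the core of compound 1.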